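The source may report more compounds than this note shows. Statements on the series, on what has been measured and on what is new or still open speak of the compounds shown alone.

Compound 1 `COc1ccccc1/C=C1\CCC/C(=C\c2cccc(OC)c2OC)C1=O` carries a 2-methoxyphenyl group on each side of its core, and in a functional assay on SW-620 cells (Homo sapiens) for cytotoxicity, read by MTT assay, with a stated time of 72 h (a lower number here means a stronger inhibitor, a higher number a weaker inhibitor), compound 1 gives > 20000 nM, which is a limit of the assay rather than a number. Compound 2 `COc1cccc(/C=C2\CCC/C(=C\c3cccc(OC)c3OC)C2=O)c1` differs from compound 1 by 3-methoxyphenyl in place of 2-methoxyphenyl on a double-bonded chain carbon bound to a double-bonded ring carbon; in this assay compound 2 gives 7000 nM, and the step amounts to an at least 2.8-fold lower number from compound 1 to compound 2 (0.45 log units; beyond the scatter). The step is stated only as a lower bound because compound 1 sits at the limit of > 20000 nM in this assay, at which 1 of the 3 values shown sits.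

Compound 3 `COc1ccccc1/C=C1\CCC/C(=C\c2ccc(OC)c(OC)c2)C1=O` keeps the 2-methoxyphenyl of compound 1 but changes the other side; how the core of compound 3 differs from the core of compound 1 is not broken down here. In this assay compound 3 gives 7800 nM, a value within the scatter of that of compound 2, so no order can be drawn between the two.

Compound 4 `COc1cccc(/C=C2\CCC/C(=C\c3ccc(OC)c(OC)c3)C2=O)c1` has not yet been measured. It differs from compound 3 by 3-methoxyphenyl in place of 2-methoxyphenyl on a double-bonded chain carbon bound to a double-bonded ring carbon, the same change, at the same place, as that from compound 1 to compound 2. On the strength of that one earlier step, compound 4 is expected to show a step of a 2.2-fold lower number from compound 3 to compound 4 (0.35 log units; beyond the scatter) in this assay, with the caveat that the earlier step rests on a limit for compound 1 and is therefore only a floor. In this assay compound 4 is estimated at 3500 nM, with a plausible range from 1500 nM to 9000 nM.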

Compound 4, half-maximal inhibitory concentration: 3700 nM
For compound 4 the middle estimate is 1.1-fold (0.02 log units) below the measured one, and the stated range covers the measured number.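

In this assay, putting 3-methoxyphenyl in place of 2-methoxyphenyl on a double-bonded chain carbon bound to a double-bonded ring carbon gives a 2.1-fold lower number from compound 3 to compound 4 (0.32 log units; beyond the scatter), so the change that lowered the number on the core of compound 1 also lowers it on the core of compound 3: the same change on two cores in this assay, an at least 2.8-fold lower number (0.45 log units; beyond the scatter) from compound 1 to compound 2 and a 2.1-fold lower number (0.32 log units; beyond the scatter) from compound 3 to compound 4; the limit leaves it open whether they differ The direction of the change therefore carries over between these two cores, although two pairs in one assay show only that much and establish no rule for the series as a whole. Compound 1 gives > 20000 nM, which is a limit of the assay and not a number, so the data do not show whether the change is worth the same on both cores or is larger on one of them.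

The compounds shown leave open whether the same step would appear on a core whose other side carries a hydroxyl group, an amine or a fluorine atom rather than methoxy groups. They also leave open whether an ethoxy group or a longer chain in place of the methoxy group of the 3-methoxyphenyl would keep the lower number that this change brings in this assay.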